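The compounds below may be only part of what the source reports. "The series", "measured", "known", "first", "only" and "open" are said of these compounds alone.

Compound 3, `CC1=CC[C@@H]([C@@](C)(O)CCCC(C)(C)NC(=S)N/N=C\c2ccccc2[N+](=O)[O-])CC1`, is one of three measured analogues on a shared core. In a functional assay on MCF7 cells (Homo sapiens) for cytotoxicity, read by sulforhodamine B assay (on this read-out higher numbers stand for lower toxicity in this test and lower numbers for higher toxicity in this test), compound 3 reaches only the limit of > 100000 nM. Compound 1, `CC1=CC[C@@H]([C@@](C)(O)CCCC(C)(C)NC(=S)N/N=C\c2ccccc2)CC1`, which carries hydrogen at the same aromatic carbon, gives 60400 nM in this assay. Compound 2, `CC1=CC[C@@H]([C@@](C)(O)CCCC(C)(C)NC(=S)N/N=C\c2ccc(N(C)C)cc2)CC1`, likewise reaches only a limit of > 100000 nM. Compound 3 therefore sits at the limit of > 100000 nM in this assay, at which 2 of the 3 values shown sit, and where it stands relative to the others is only partly readable: an at least 1.6-fold higher number from compound 1 to compound 3 (0.21 log units; that floor lies within the scatter), an at least 1.6-fold higher number from compound 1 to compound 2 (0.21 log units; that floor lies within the scatter), and a step that the two limits leave unreadable from compound 2 to compound 3.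

Compound 4, `CC1=CC[C@@H]([C@@](C)(O)CCCC(C)(C)NC(=S)N/N=C\c2ccccc2Cl)CC1`, differs from compound 3 in a single place: chloro in place of nitro on an aromatic carbon. The measured steps that touch this position are the one from hydrogen to nitro, an at least 1.6-fold higher number from compound 1 to compound 3 (0.21 log units; that floor lies within the scatter), and the unreadable exchange a step that the two limits leave unreadable from compound 2 to compound 3; neither gives a direction for swapping nitro against chloro. Compound 1 gives 60400 nM with no substituent at that carbon, and every measured number in this assay lies in the same weak region. Compound 4 is therefore expected to remain there, with an expected step of a number no higher from compound 3 to compound 4 (the limit leaves the size open), none beyond the scatter. Compound 4 is estimated at 100000 nM, with an expected range from 40000 nM to 250000 nM.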

Compound 4, concentration lethal to 50% of the cells: > 100000 nM
Compound 4: a limit, no number (the forecaster's own chance of this, stated with the estimate: 55%); the middle value lies on the limit itself.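

Compound 4 gives a limit and no number in this assay, so chloro now joins nitro at this aromatic carbon with the same kind of result: the limit of > 100000 nM in this assay, at which 3 of the 4 values shown sit. Against hydrogen at that carbon, the change gives an at least 1.6-fold higher number from compound 1 to compound 4 (0.21 log units; that floor lies within the scatter) and so shows no separation beyond the scatter, while compound 1 remains the only analogue with a number. The steps from compound 2 and compound 3 to compound 4 cannot be read, as both ends of each are limits, which leaves chloro and nitro unordered at this position.

As far as these compounds go, whether a methoxy group or a carboxylic acid on this aromatic carbon would give a number rather than a limit remains open. Also open is whether an amine or a longer chain in place of the phenyl ring would move the result clearly away from that of compound 1, as no step shown here goes beyond the scatter.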